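The source may report more compounds than this note shows. Statements on the series, on what has been measured and on what is new or still open speak of the compounds shown alone.

Compound 3 `O=C(NCc1ccc(CNS(=O)(=O)c2ccccc2)cc1)c1cccnc1` is one of three compounds that share a core and differ only in the aromatic ring attached to the carbonyl carbon. In an assay on MDA-MB-231 cells for binding affinity to C-X-C chemokine receptor type 4 (Homo sapiens), read by immunofluorescence and microscopy, with stated times of 10 min and 30 min (on this read-out higher numbers stand for an effect only at larger amounts of compound and lower numbers for an effect already at smaller amounts), compound 3 gives 10 nM. Compound 1 `O=C(NCc1ccc(CNS(=O)(=O)c2ccccc2)cc1)c1ccncc1` gives 10 nM in this assay, and compound 3 stands level with it at the digits shown; the two together are the lowest of the three numbers. Compound 2 `O=C(NCc1ccc(CNS(=O)(=O)c2ccccc2)cc1)c1cccc(Cl)c1` gives 1000 nM in this assay, so that a 100-fold lower number from compound 2 to compound 3 (2.00 log units; beyond the scatter). Compound 4 `Cc1cccc(C(=O)NCc2ccc(CNS(=O)(=O)c3ccccc3)cc2)c1` has not yet been measured in this assay. 3-methylphenyl in place of pyridin-3-yl on a carbonyl carbon Two measured steps bear on this change, as each exchanges a pyridinyl ring for a substituted phenyl ring on the carbonyl carbon: a 100-fold higher number from compound 1 to compound 2 (2.00 log units; beyond the scatter), and, read from the other side, a 100-fold lower number from compound 2 to compound 3 (2.00 log units; beyond the scatter). Compound 4 carries a 3-methylphenyl ring rather than the 3-chlorophenyl ring of compound 2, and nothing measured here shows how these two rings compare, so the size of the step is uncertain. Compound 4 is therefore expected to give a clearly higher number in this assay, roughly a 50-fold higher number from compound 3 to compound 4 (1.70 log units; beyond the scatter). For compound 4 the estimate in this assay is 500 nM, with a range from 50 nM to 3000 nM.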

Compound 4, effective concentration (reported as EC, without a stated level of effect): 1000 nM
Compound 4: the middle estimate sits 2.0-fold (0.30 log units) below what was measured; measured number inside the range.
By their numbers in this assay, from the lowest: compounds 1 and 3 (each within the scatter of the next); then compounds 2 and 4 (each within the scatter of the next).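

In this assay the exchange of pyridin-3-yl for 3-methylphenyl on a carbonyl carbon gives a 100-fold higher number from compound 3 to compound 4 (2.00 log units; beyond the scatter), and the exchange from pyridin-4-yl gives a 100-fold higher number from compound 1 to compound 4 (2.00 log units; beyond the scatter), so among these four compounds both pyridinyl rings now stand apart from two substituted phenyl rings rather than from one, and no compound here goes against that split. Methyl in place of chloro on an aromatic carbon gives no change at the digits printed from compound 2 to compound 4 (within the scatter), which shows that the higher number at this position is not particular to the chloro group of compound 2. Nothing available explains this difference between the rings.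

Each step from a pyridinyl to a phenyl ring here also adds a substituent, so the compounds shown do not separate the loss of the ring nitrogen from the gain of the methyl or chloro group; a plain phenyl ring or a methyl-bearing pyridin-3-yl ring would bear on that. Also open, as far as these compounds go, is how pyridin-2-yl, or a phenyl ring carrying an amine or a carboxylic acid, would read at this carbonyl carbon.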